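The source may report more compounds than this note shows. Statements on the series, on what has been measured and on what is new or still open speak of the compounds shown alone.

Compound 2 `C=C1C[C@]23C[C@@]1(O)CC[C@H]2c1ccc(OS(=O)(=O)c2ccc(C)cc2)c(C)c1[C@@H]3Cn1cc(-c2ccc(C)cc2)nn1` and compound 1 `C=C1C[C@]23C[C@@]1(O)CC[C@H]2c1ccc(OS(=O)(=O)c2ccc(C)cc2)c(C)c1[C@@H]3Cn1cc(-c2ccc(OC)cc2)nn1` share one core and differ only by methoxy in place of methyl on an aromatic carbon. In a functional assay on A549 cells (Homo sapiens) for cytotoxicity, read by MTT assay, with a stated time of 4 days (a higher number here means a weaker inhibitor, a lower number a stronger inhibitor), compound 2 reaches only a limit of the assay, not a number, > 20000 nM. Compound 1 likewise reaches only a limit in this assay, > 20000 nM. The step that the two limits leave unreadable from compound 2 to compound 1 therefore cannot be read because of the limit of > 20000 nM in this assay, at which 2 of the 3 values shown sit. Compound 3 `C=C1C(=O)[C@]23C[C@@]1(O)CC[C@H]2c1ccc(O)c(C)c1[C@@H]3Cn1cc(-c2ccc(C)cc2)nn1` rests on a second core; the difference between the two cores is not broken down here. In this assay, within the data shown here, compound 3 gives 1260 nM, the only actual number among the three measured compounds. Compound 4 `C=C1C(=O)[C@]23C[C@@]1(O)CC[C@H]2c1ccc(O)c(C)c1[C@@H]3Cn1cc(-c2ccc(OC)cc2)nn1` arises from compound 3 by methoxy in place of methyl on an aromatic carbon, the same change that separates compound 2 from compound 1. Since the step that the two limits leave unreadable from compound 2 to compound 1 gives no readable size, there is no measured guide to how this change acts on the second core. The expected step for compound 4 is a 1.2-fold higher number from compound 3 to compound 4 (0.08 log units; within the scatter), a size within the usual scatter, resting only on the absence of a readable step. Compound 4 is accordingly estimated at 1500 nM in this assay, between 500 nM and 5000 nM.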

Compound 4, half-maximal inhibitory concentration: 1250 nM
The estimate for compound 4 lay 1.2-fold (0.08 log units) above the measured number; the measured number falls inside the stated range.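

On the core of compound 3, replacing 4-methylphenyl with 4-methoxyphenyl gives a 1.0-fold lower number from compound 3 to compound 4 (0.00 log units; within the scatter) in this assay, so this pair cannot be told apart in this assay. This shows that on this one core, in this one pair, the methoxy and methyl compounds read alike, but a single pair sets no rule for the series. Whether the result carries over from one core to the other cannot be said, and the step from compound 2 to compound 1 cannot be read because both compounds sit at a limit and not at a number: the limit of > 20000 nM in this assay, at which 2 of the 4 values shown sit.

The compounds shown leave open how an amine, a carboxylic acid or a longer chain such as ethoxy on that aromatic carbon would read against methyl and methoxy. Also open is which of the differences between the two cores matters in this assay, since no pair shown separates them one place at a time.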